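A few compounds are considered here, and "the series" means these few. Any claim that something is new, unique, unknown or untested is made for them only; others in the source may bear on it.

Three compounds sharing one core were tested in a functional assay on HCT-15 cells (Homo sapiens) for inhibition, read by sulforhodamine B assay, with a stated time of 48 h; on this read-out lower numbers stand for stronger inhibition of growth and higher numbers for weaker inhibition of growth. Compound 1 `Nc1cc(N)c2nc(-c3ccccc3)c(Oc3ccc(Cl)c(Cl)c3)nc2c1` gives only a limit of the assay, < 100000 nM. Compound 2 `CCOC(=O)[C@H](CCC(=O)O)NC(=O)c1ccc(CNc2nc3cc(N)cc(N)c3nc2-c2ccccc2)cc1` likewise returns a limit, < 100000 nM. Compound 3 `Nc1cc(N)c2nc(-c3ccccc3)c(NCc3ccc(Cl)c(Cl)c3)nc2c1` also sits at a limit in this assay, < 100000 nM. Within the data shown here, compound 3 therefore cannot be ranked against the others: every value shown is a limit, as the limit of < 100000 nM in this assay, at which 3 of the 3 values shown sit, records, and no step between measured compounds can be read. Compound 4 `COc1ccc(CNc2nc3cc(N)cc(N)c3nc2-c2ccccc2)cc1` differs from compound 3 by 4-methoxyphenyl in place of 3,4-dichlorophenyl on a saturated chain carbon bound to a nitrogen on an aromatic ring. Among the measured compounds shown here, with all measured values at the limit, the data give no direction for this step. The expected step that the limit leaves unreadable from compound 3 to compound 4 is none beyond the scatter. For compound 4 the estimate in this assay is 30000 nM, within 5000 nM to 100000 nM, and a limit rather than a number is likely.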

Compound 4, concentration for total growth inhibition: 34700 nM
The estimate for compound 4 lay 1.2-fold (0.06 log units) below the measured number, and the stated range covers the measured number.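

No step from compound 3 to compound 4 can be read, because compound 3 gives only a limit of the assay: the limit of < 100000 nM in this assay, at which 3 of the 4 values shown sit.

The compounds shown leave open whether 3,4-dichlorobenzyl or 4-methoxybenzyl gives the stronger inhibition of growth.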